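This account rests on a few compounds, and the source may have more. Where it says the series, first, only, none or still open, it means among the compounds named here.

Compound 1 `Cc1ccc2c(NCc3ccc(NC(=O)C4CCN(Cc5cc(Cl)ccn5)CC4)cc3)nc(N(C)C)nc2c1`: in a functional assay on SV5A8 cells (Homo sapiens) for cytotoxicity (on this read-out lower numbers stand for stronger inhibition and higher numbers for weaker inhibition), compound 1 gives > 5400 nM, which is a limit of the assay and not a number.
Compound 2 `Cc1ccc2c(NCc3ccc(NC(=O)C4CCN(Cc5ccccc5)CC4)cc3)nc(N3CCN[C@@H](C)C3)nc2c1`: in this assay compound 2 gives > 8860 nM, again only a limit.
Compound 3 `Cc1ccc2c(NCc3ccc(NC(=O)C4CCN(CC5CCNCC5)CC4)cc3)nc(N(C)C)nc2c1`: in this assay compound 3 gives > 8070 nM, also a limit.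

Compound 3 therefore stands only at a limit (the limit of > 8070 nM in this assay, at which 1 of the 3 values shown sits), and the two further values shown are limits as well the limit of > 5400 nM in this assay, at which 1 of the 3 values shown sits (the limit of > 8860 nM in this assay, at which 1 of the 3 values shown sits). Among the measured compounds shown here, the single step between measured compounds that differ in one place, a step that the two limits leave unreadable from compound 1 to compound 3, runs between two limits and its size cannot be read.

Compound 4 `COc1ccc(CN2CCC(C(=O)Nc3ccc(CNc4nc(N(C)C)nc5cc(C)ccc45)cc3)CC2)cc1` differs from compound 3 by 4-methoxyphenyl in place of piperidin-4-yl on a saturated chain carbon bound to an amine nitrogen in a ring. For the measured compounds named here, no measured step bears directly on this change; the only step available, a step that the two limits leave unreadable from compound 1 to compound 3, has no readable size, and compound 2 shows nothing more than that it also sits at a limit. With three limits and no readable step, the expectation for compound 4 is that it again reaches no number in this assay. The step that the limit leaves unreadable from compound 3 to compound 4 is expected to be none that can be read beyond the scatter. Compound 4 is estimated at 10000 nM, within a range from 3000 nM to 30000 nM.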

Compound 4, half-maximal inhibitory concentration: > 6180 nM
Compound 4: only a limit was reported (the forecaster's own chance of this, stated with the estimate: 80%); the middle value lies beyond the limit too.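

Compound 4, like compound 1 and compound 3, stands only at a limit, so the steps joining compound 4 to compound 1 and to compound 3 cannot be read. The compounds shown leave open how far any of these group changes shifts the read-out, as none reaches a number.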